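The source may hold more compounds than are shown below. What is called first, only, known or untested is meant among the compounds shown, and "the series" means these compounds.

Compound 1 `CCn1c(=O)[nH]c2ccc(OCCOc3ccc(Cl)cc3)cc21` and compound 2 `CC(C)n1c(=O)[nH]c2ccc(OCCOc3ccc(Cl)cc3)cc21` share one core and differ only by methyl in place of hydrogen on a saturated chain carbon bound to an aromatic nitrogen and a saturated chain carbon. In an assay on cells for inhibition of Amine oxidase [flavin-containing] B (Homo sapiens), read by fluorescence, with stated times of 30 min and 15 min, tested at 1 uM (a lower number here means less inhibition, a higher number more inhibition at the concentration tested (going by the name of the read-out)), compound 1 gives 7.24%, while compound 2 gives 18.2%, so this change produced a number 11 percentage points higher from compound 1 to compound 2 (beyond the scatter). Compound 3 `Cn1c(=O)[nH]c2ccc(OCCCc3ccccc3)cc21` is built on a different core, and the difference between the two cores is not broken down here. In this assay compound 3 gives 14%, a number that sits within the usual scatter of both earlier compounds, so no order among the three can be read from it. Compound 4 `CCn1c(=O)[nH]c2ccc(OCCCc3ccccc3)cc21` has not yet been measured. It differs from compound 3 by methyl in place of hydrogen on a saturated chain carbon bound to an aromatic nitrogen, the same kind of change as that between the first two compounds, though not the same: in the earlier pair the carbon was bound to an aromatic nitrogen and a saturated chain carbon, whereas here it is bound to an aromatic nitrogen only. Going by the values given here, the expected step is a number 10 percentage points higher from compound 3 to compound 4 (within the scatter), resting on the single earlier example a number 11 percentage points higher from compound 1 to compound 2 (beyond the scatter) rather than on any wider pattern. Compound 4 is therefore estimated at about 24%, most likely between 10% and 40%.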

Compound 4, a percentage reported as inhibition, at one concentration (the size of the read-out at that concentration, not a potency): 4.56%
Compound 4: the middle estimate sits 19.4 percentage points above what was measured, outside the stated range (below it).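

In this assay, methyl in place of hydrogen on a saturated chain carbon bound to an aromatic nitrogen gives a number 9.4 percentage points lower from compound 3 to compound 4 (within the scatter), so the rise seen on the core of compound 1 does not reappear on the core of compound 3. The two steps clearly differ: the same change on two cores in this assay, a number 11 percentage points higher (beyond the scatter) from compound 1 to compound 2 and a number 9.4 percentage points lower (within the scatter) from compound 3 to compound 4, 20.4 percentage points apart, beyond the scatter of two such steps This shows that a single example of this change is a poor guide to its effect on another core in this series, but it does not explain the difference, and with the step on the core of compound 3 lying within the scatter, it does not establish that the change lowers the number there.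

The compounds shown leave open how a longer chain, such as propyl, or a chain ending in an amine would read at this position on either core. Each compound is also shown at only one concentration, which leaves its potency open.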